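The compounds below may be only part of what the source reports. "The series", "measured", "known", "first", "only" and "open" are said of these compounds alone.

Compound 1, `COc1ccccc1-c1ccc(CNC(=O)NC2CCN(Cc3ccc(C)cc3)CC2)cc1`, gives 642 nM in an in vitro functional assay on HEK293 cells for antagonist activity at melanin-concentrating hormone receptor 1 (Homo sapiens), read by GTPgammaS binding, with a stated time of 45 min; a lower number here means a stronger inhibitor, a higher number a weaker inhibitor. Compound 2, `Cc1ccc(CN2CCC(NC(=O)NCc3ccc(-c4ccccc4)cc3)CC2)cc1`, gives 1060 nM in the same assay. The change between them, (hydrogen in place of methoxy on an aromatic carbon), made the step of a 1.7-fold higher number from compound 1 to compound 2 (0.22 log units; within the scatter).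

Compound 3, `COc1ccc(-c2ccc(CN(CCC3CCN(Cc4ccc(C)cc4)CC3)C(=O)NC(C)(C)COC(C)=O)cc2)cc1`, gives 647 nM; how its core differs from the core of compound 1 is not broken down here. Compound 4, `CC(=O)OCC(C)(C)NC(=O)N(CCC1CCN(Cc2ccc(C)cc2)CC1)Cc1ccc(-c2ccccc2)cc1`, has not yet been measured. It differs from compound 3 by hydrogen in place of methoxy on an aromatic carbon. This is the same kind of change as that from compound 1 to compound 2, but the surroundings differ: in the first pair the methoxy sits ortho to a large group, in the second pair para to a large group.

On the strength of a 1.7-fold higher number from compound 1 to compound 2 (0.22 log units; within the scatter), a step of about a 1.5-fold higher number from compound 3 to compound 4 (0.17 log units; within the scatter) is expected for compound 4. Compound 4 is thus estimated at 950 nM, within 400 nM to 2500 nM.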

Compound 4, antagonist equilibrium constant: 366 nM
Compound 4: middle estimate off by 2.6-fold (0.41 log units), on the high side; the measured number lies below the stated range.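

Going from 4-methoxyphenyl to phenyl gave a 1.8-fold lower number from compound 3 to compound 4 (0.25 log units; within the scatter) in this assay. Set beside the earlier step, the same change did not carry over as one fixed step between these two cores: the same change on two cores in this assay, a 1.7-fold higher number (0.22 log units; within the scatter) from compound 1 to compound 2 and a 1.8-fold lower number (0.25 log units; within the scatter) from compound 3 to compound 4, 2.9-fold (0.47 log units) apart, beyond the scatter of two such steps. This shows that, in this series, the step measured on the core of compound 1 was not a reliable guide to the step on the core of compound 3, but each step alone stays within the scatter, and the two pairs do not show why the steps part or what the change would do on a further core.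

On these data alone, what an ethoxy chain, a hydroxy group or an amine in place of the methoxy would do on either core remains open.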